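Fluoro for Methyl on a Weakly Cytotoxic Thiazolidine Imine

This account rests on a few compounds, and the source may have more. Where it says the series, first, only, none or still open, it means among the compounds named here.

Measured compounds:
- compound 1, `COc1ccc(/C=C2/CN(C)/C(=N/c3ccc(C)cc3)S2)cc1`: 65700 nM
- compound 2, `C=C1CN/C(=N/c2ccccc2)S1`: > 100000 nM
- compound 3, `COc1ccc(/C=C2\S/C(=N\c3ccccc3)N(C)C2=O)cc1`: > 100000 nM

Of the compounds shown here, three have been tested in an ADME assay on TERT-RPE1 cells (Homo sapiens) for cytotoxicity, read by MTT assay, with a stated time of 72 h; on this read-out higher numbers stand for weaker inhibition and lower numbers for stronger inhibition. Compound 1 is the only one of them to return a number, giving 65700 nM in this assay. Compound 2 returns > 100000 nM, which is a limit of the assay rather than a number. Compound 3 likewise returns > 100000 nM, again a limit of the assay. For the measured compounds named here, compound 1 therefore stands as the one compound with a measurable value, while the other two sit at the limit of > 100000 nM in this assay, at which 2 of the 3 values shown sit.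

Going by the values given here, no pair of the measured compounds differs in only one place, so no single step is available to calibrate the effect of a small change. The unmeasured compound 4, `COc1ccc(/C=C2/CN(C)/C(=N/c3ccc(F)cc3)S2)cc1`, differs from compound 1 by fluoro in place of methyl on an aromatic carbon. Given that compound 1 gives 65700 nM, the step is expected to be small, with a 1.2-fold higher number from compound 1 to compound 4 (0.09 log units; within the scatter), and in no clear direction beyond the usual scatter. Compound 4 is accordingly estimated to give 80000 nM in this assay, within a range from 30000 nM to 200000 nM.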

Compound 4, half-maximal inhibitory concentration: 42800 nM
Estimate against measurement, compound 4: 1.9-fold (0.27 log units) above, and the stated range covers the measured number.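

For the compounds shown here, the change from 4-methylphenyl to 4-fluorophenyl provides the first step in this assay between two compounds that differ in only one place, and it reads a 1.5-fold lower number from compound 1 to compound 4 (0.19 log units; within the scatter). At this position on the aromatic ring, para to a large group, methyl and fluoro therefore cannot be told apart on this read-out, and the swap leaves the value where a repeated measurement might have put it. The two remaining compounds stand at a limit of the assay, which is not a number, so this single step is all the calibration the series has: the limit of > 100000 nM in this assay, at which 2 of the 4 values shown sit.

As far as these compounds go, what remains open is whether a group of a different kind at this position, such as an amine, a carboxylic acid or a longer chain, would move the number beyond the scatter. A single step at one place also leaves open how the methoxy group, or any other part of the core of compound 1, bears on the value in this assay.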